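A few compounds are considered here, and "the series" means these few. Any claim that something is new, unique, unknown or untested is made for them only; others in the source may bear on it.

Measured so far in a functional assay on K562 cells (Homo sapiens) for antiproliferative activity, read by MTT assay, with a stated time of 48 h; a lower number here means a stronger inhibitor, a higher number a weaker inhibitor:
Compound 1 `CC(C)(C)OC(=O)CN1C(=O)C2(C(C#N)=C(N)Oc3cc4oc(-c5ccccc5)cc(=O)c4c(O)c32)c2ccccc21`: a limit of the assay, > 50000 nM.
Compound 2 `N#CC1=C(N)Oc2cc3oc(-c4ccccc4)cc(=O)c3c(O)c2C12C(=O)Nc1ccccc12`: 36400 nM.
Compound 3 `Cc1ccc2c(c1)C1(C(=O)N2)C(C#N)=C(N)Oc2cc3oc(-c4ccccc4)cc(=O)c3c(O)c21`: a limit of the assay, > 50000 nM.

Among the compounds with values here, compound 2 carries the only number in this assay; the two other values are limits (the limit of > 50000 nM in this assay, at which 2 of the 3 values shown sit). The step of an at least 1.3-fold lower number from compound 1 to compound 2 (0.13 log units; that floor lies within the scatter), hydrogen in place of (tert-butoxycarbonyl)methyl on the amide-type ring nitrogen, is a floor only. The step of an at least 1.3-fold higher number from compound 2 to compound 3 (0.13 log units; that floor lies within the scatter), methyl in place of hydrogen on an aromatic carbon, is likewise a floor. Compound 4 `N#CC1=C(N)Oc2cc3oc(-c4ccccc4)cc(=O)c3c(O)c2C12C(=O)Nc1cc(Cl)ccc12` differs from compound 2 by chloro in place of hydrogen on an aromatic carbon. The closest comparison is the methyl step to compound 3, which carried the value out to the assay limit; the chloro change is also a small substituent on an aromatic carbon of the same ring, so a shift in the same direction, possibly again to the limit, is the working expectation, though both measured floors lie within the scatter and a value close to that of compound 2 cannot be excluded. Compound 4 is therefore expected at 45000 nM, between 15000 nM and 150000 nM. The expected step from compound 2 is a 1.2-fold higher number from compound 2 to compound 4 (0.09 log units; within the scatter).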

Compound 4, half-maximal inhibitory concentration: 9250 nM
The estimate for compound 4 lay 4.9-fold (0.69 log units) above the measured number; the whole stated range lies above it.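

In this assay, chloro in place of hydrogen gives a 3.9-fold lower number from compound 2 to compound 4 (0.59 log units; beyond the scatter), the only step among the compounds shown that can be read as a size and the only one beyond the scatter. This aromatic carbon, meta to a fused ring and para to a fused ring, is therefore a place where a single chlorine atom lowers the number instead of moving it towards the limit. The steps to or from compounds 1 and 3 cannot be read as sizes because their values are limits: the limit of > 50000 nM in this assay, at which 2 of the 4 values shown sit.

From the compounds shown here alone, whether the drop is specific to chloro stays open, and fluoro, methoxy or an amine on this same carbon would test that. Also open, going by these compounds, is whether chloro keeps this effect with a (tert-butoxycarbonyl)methyl group on the amide-type ring nitrogen.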